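Changing the Phenyl Group of Compound 2

This account rests on a few compounds, and the source may have more. Where it says the series, first, only, none or still open, it means among the compounds named here.

Compound 1 `COc1ccc(C2=C(c3cc(OC)c(OC)c(OC)c3)C(=O)C(OC(C)=O)C2)cc1OC(C)C` gives > 100 ug/mL (a limit)
Compound 2 `COc1ccc(OC)c(C2=C(c3cc(OC)c(OC)c(OC)c3)C(=O)CC2O[SiH2]C(C)(C)C)c1` gives 9.5 ug/mL
Compound 3 `COc1ccc(OC)c(C2=C(c3cc(OC)c(OC)c(OC)c3)C(=O)CC2O)c1` gives > 100 ug/mL (a limit)

In an ADME assay on HEK293 cells (Homo sapiens) for cytotoxicity, read by MTT assay, with a stated time of 72 h (a lower number here means a stronger inhibitor, a higher number a weaker inhibitor), compound 2 at 9.5 ug/mL is the only one of the three with a number. The other two values are limits. Compound 4 `COCOc1cc(C2=C(c3cc(OC)c(OC)c(OC)c3)C(=O)CC2O[SiH2]C(C)(C)C)ccc1OC` is the next to be read. The change is 4-methoxy-3-(methoxymethoxy)phenyl in place of 2,5-dimethoxyphenyl on a double-bonded ring carbon and amounts to 4-methoxy-3-(methoxymethoxy)phenyl in place of 2,5-dimethoxyphenyl on a double-bonded ring carbon. Within the data shown here, the single measured step is an at least 10-fold higher number from compound 2 to compound 3 (1.02 log units; beyond the scatter) and it removes the silicon-bearing group on the oxygen. Compound 4 keeps that group, so this large step is not expected to repeat. Among the measured compounds shown here, no measured step changes the phenyl group, which leaves the value of compound 2 at 9.5 ug/mL as the only anchor. The expected step is a 1.3-fold higher number from compound 2 to compound 4 (0.10 log units; within the scatter) and is estimated to stay within the scatter. For compound 4 the estimated value in this assay is 12 ug/mL with an expected range from 4 ug/mL to 40 ug/mL.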

Compound 4, half-maximal inhibitory concentration: > 100 ug/mL
Compound 4: a limit, no number; the forecaster's own chance of this, stated with the estimate: 10%; middle value at least 8.3-fold (0.92 log units) away from the limit.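

Among these compounds, the earlier step, an at least 10-fold higher number from compound 2 to compound 3 (1.02 log units; beyond the scatter), showed only that the number in this assay depends on the silicon-bearing group on the oxygen; this result shows that it also depends on the phenyl group on the double-bonded ring carbon. With that silicon-bearing group kept, 4-methoxy-3-(methoxymethoxy)phenyl in place of 2,5-dimethoxyphenyl gives an at least 10-fold higher number from compound 2 to compound 4 (1.02 log units; beyond the scatter), a large step beyond the scatter. Its size rests on a limit and not on two numbers: the limit of > 100 ug/mL in this assay, at which 3 of the 4 values shown sit.

The compounds shown do not separate the effect of the methoxymethoxy group from that of the different arrangement of substituents on the phenyl ring, since both change in this one step. On these data alone, it also stays open whether a phenyl group carrying a free hydroxy group, an amine or a carboxylic acid would give a number in this assay.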